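Dimethylamino in Place of Pyrrolidin-1-yl: Cytotoxicity Outlook

The source may report more compounds than this note shows. Statements on the series, on what has been measured and on what is new or still open speak of the compounds shown alone.

In an ADME assay on CCRF-HSB-2 cells (Homo sapiens) for cytotoxicity, with a stated time of 7 days (on this read-out higher numbers stand for lower toxicity in this test and lower numbers for higher toxicity in this test), compound 3 `Nc1nc(N2CCCC2)c2ncn(/C=C3/CC3(CO)CO)c2n1` gives only a limit, > 20000 nM. Compound 1 `CCCCCCCCOc1nc(N)nc2c1ncn2/C=C1/CC1(CO)CO` likewise reaches only a limit, > 20000 nM. Compound 2 `CCCOc1nc(N)nc2c1ncn2/C=C1/CC1(CO)CO` also stops at a limit, > 20000 nM. The steps between them, a step that the two limits leave unreadable from compound 1 to compound 2, a step that the two limits leave unreadable from compound 1 to compound 3 and a step that the two limits leave unreadable from compound 2 to compound 3, therefore cannot be sized, and all three values sit together at the limit of > 20000 nM in this assay, at which 3 of the 3 values shown sit. Compound 4 `CN(C)c1nc(N)nc2c1ncn2/C=C1/CC1(CO)CO` differs from compound 3 by dimethylamino in place of pyrrolidin-1-yl on an aromatic carbon. The measured steps bear on it only in that every exchange of this group so far left the read-out at the limit, so no step beyond the scatter is expected, with a number no higher from compound 3 to compound 4 (the limit leaves the size open) as the expected step. Compound 4 is therefore estimated to give 20000 nM in this assay, most likely again as a limit, with a range of 10000 nM to 40000 nM.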

Compound 4, half-maximal cytotoxic concentration: > 20000 nM
Compound 4: a limit, no number; the forecaster's own chance of this, stated with the estimate: 80%; the middle value lies on the limit itself.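

Compound 4 also stops at a limit, so no step from compound 1, compound 2 or compound 3 to it can be read: the limit of > 20000 nM in this assay, at which 4 of the 4 values shown sit.

The compounds shown leave open where any of the four true values lies, and whether exchanging the group on that aromatic carbon changes cytotoxicity at all.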